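Trifluoromethyl to Isopropyl on Two Compounds Beyond the Limit

This account rests on a few compounds, and the source may have more. Where it says the series, first, only, none or still open, it means among the compounds named here.

Compound 1 `CSc1ccc(C#Cc2ccc(C(=O)N3CCC[C@@H](CO)C3)cc2)cc1`: > 10000 nM
Compound 2 `O=C(c1ccc(C#Cc2ccc(OC(F)(F)F)cc2)cc1)N1CCC[C@@H](CO)C1`: > 10000 nM

Compound 1 was tested in a functional assay on TREX cells for negative allosteric modulation of metabotropic glutamate receptor 3 (Rattus norvegicus), read by calcium flux, with a stated time of 2.5 min (on this read-out higher numbers stand for weaker inhibition and lower numbers for stronger inhibition), where compound 1 gave > 10000 nM, a limit of the assay rather than a number. Compound 2 in this assay gave > 10000 nM, again only a limit. The step that the two limits leave unreadable from compound 1 to compound 2 is therefore unreadable, since both values sit at the limit of > 10000 nM in this assay, at which 2 of the 2 values shown sit, and neither shows how far inhibition actually falls short.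

Compound 3 `CC(C)Oc1ccc(C#Cc2ccc(C(=O)N3CCC[C@@H](CO)C3)cc2)cc1` differs from compound 2 in isopropyl in place of trifluoromethyl on an oxygen on an aromatic ring. Within the data shown here, no measured step covers this change, and the only step between measured compounds gives no size at all. Nothing in the data points to a gain in inhibition for a new group at this place, so compound 3 is expected to stay weak.

Compound 3 is estimated at 15000 nM, with a range from 3000 nM to 60000 nM. The expected step is a step that the limit leaves unreadable from compound 2 to compound 3, most likely again reported only as a limit.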

Compound 3, half-maximal inhibitory concentration: > 10000 nM
Compound 3: a limit, no number; the forecaster's own chance of this, stated with the estimate: 70%; the middle value lies beyond the limit too.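

In this assay compound 3 gives > 10000 nM, a limit and not a number. Among these compounds, no step among compound 1, compound 2 and compound 3 can be read, since all three stop at the same point: the limit of > 10000 nM in this assay, at which 3 of the 3 values shown sit. Left open is whether methylsulfanyl, trifluoromethoxy and isopropoxy differ at all in inhibition.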